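Swapping ethyl for methoxy on a carboxy-bearing core

The source may hold more compounds than are shown below. What is called first, only, known or untested is meant among the compounds shown, and "the series" means these compounds.

In a functional assay on A-375 cells (Homo sapiens) for antiproliferative activity, read by MTT assay, with a stated time of 24 h (a higher number here means a weaker inhibitor, a lower number a stronger inhibitor), compound 1 `CCc1ccc2nc(C(=O)Nc3c(F)cc(-c4cccc(F)c4)cc3F)c(C)c(O)c2c1` gives 8130 nM, compound 2 `Cc1c(C(=O)Nc2ccc(-c3ccccc3)cc2)nc2ccccc2c1O` gives 75500 nM and compound 3 `CCc1ccc2nc(C(=O)Nc3c(F)cc(-c4cccc(F)c4)cc3F)c(C)c(C(=O)O)c2c1` gives 57800 nM. The numbers for compound 2 and compound 3 lie within the usual scatter of each other, so neither can be ranked above the other. Compound 1 stands clearly apart from compound 3: a 7.1-fold higher number from compound 1 to compound 3 (0.85 log units; beyond the scatter), a change of carboxy in place of hydroxy on an aromatic carbon.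

Compound 4 `COc1ccc2nc(C(=O)Nc3c(F)cc(-c4cccc(F)c4)cc3F)c(C)c(C(=O)O)c2c1` differs from compound 3 in a single place, with methoxy in place of ethyl on an aromatic carbon. The two groups are the same size by heavy-atom count, and the new one adds a hydrogen-bond acceptor. Going by the values given here, no measured pair tests this swap. Among the compounds with values here, the one measured step, a 7.1-fold higher number from compound 1 to compound 3 (0.85 log units; beyond the scatter), concerns a different pair of groups, so it offers a sense of how far a single change can move this series, but no direction for this one. With nothing pointing either way, no step beyond the scatter is expected in this assay. The expected change is a 1.2-fold lower number from compound 3 to compound 4 (0.06 log units; within the scatter), though a larger move remains possible. Compound 4 is estimated at 50000 nM, with an expected range from 20000 nM to 120000 nM.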

Compound 4, half-maximal inhibitory concentration: > 100000 nM
Compound 4 ended at the assay's limit; the forecaster's own chance of this, stated with the estimate: 10%; at least 2.0-fold (0.30 log units) between middle value and limit.
By their numbers in this assay, from the lowest: compound 1; then compounds 3 and 2 (each within the scatter of the next). At a limit, above all of these: compound 4.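

In this assay, compound 4 gives > 100000 nM, which is a limit of the assay and not a number. Going by these compounds alone, no earlier step touches this position, an aromatic carbon of the shared core, and here methoxy in place of ethyl brings no gain on the carboxy-bearing core, the step reading an at least 1.7-fold higher number from compound 3 to compound 4 (0.23 log units; that floor lies within the scatter). Only a floor of that step can be read, so its true size stays unknown, and compound 4 is the one compound shown that sits at the top of the measurable range: the limit of > 100000 nM in this assay, at which 1 of the 4 values shown sits.

The compounds shown leave open how this position responds to other groups, such as an amine, a chlorine atom or a longer chain like propyl, any of which could show whether the position tolerates change at all on this core. They also leave open whether methoxy in place of ethyl would act the same way on the hydroxy-bearing core of compound 1, which gives 8130 nM, where a result inside the measurable range would give the swap a readable size.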